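Cyclopentyl in place of cyclohexyl: expected half-life

The source may report more compounds than this note shows. Statements on the series, on what has been measured and on what is new or still open speak of the compounds shown alone.

For the measured compounds named here, in an in vitro ADME assay on the whole organism (small intestine) for pharmacokinetics, with Rattus norvegicus as the target (a higher number here means that the compound lasts longer, a lower number that the compound disappears faster), compound 2 `C/C(=C\c1ccc(C(=O)Oc2ccc(C(=N)N)cc2)cc1)C(=O)N(CC(=O)O)C1CCCCC1` gives 0.817 h, the only actual number so far. Compound 1 `CCOC(=O)CN(C(=O)/C(C)=C/c1ccc(C(=O)Oc2ccc(C(=N)N)cc2)cc1)C1CCCC1` reads > 1 h, which is a limit of the assay and not a number. Compound 3 `C/C(=C\c1ccc(C(=O)Oc2ccc(C(=N)N)cc2)cc1)C(=O)N(CC(=O)O)C1CCCC1` carries cyclopentyl in place of cyclohexyl on an amide-type nitrogen. Going by the values given here, no measured pair isolates this change, so the estimate starts from compound 2 at 0.817 h, and no step beyond the usual scatter is expected in this assay. The expected step is a 1.0-fold lower number from compound 2 to compound 3 (0.01 log units; within the scatter). For compound 3 the estimated half-life is 0.8 h, with an expected range of 0.45 h to 1.4 h.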

Compound 3, half-life: 0.7 h
Compound 3: middle estimate off by 1.1-fold (0.06 log units), on the high side, and the stated range covers the measured number.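

In this assay the ring on the amide-type nitrogen now has a matched pair: cyclopentyl in place of cyclohexyl gives a 1.2-fold lower number from compound 2 to compound 3 (0.07 log units; within the scatter), so the half-life does not separate these two rings. Removing the ethyl from the ester gives an at least 1.4-fold lower number from compound 1 to compound 3 (0.15 log units; that floor lies within the scatter). That step is only a floor because compound 1 carries a limit and not a number: the limit of > 1 h in this assay, at which 1 of the 3 values shown sits.

Still open, as far as these compounds go, is how cyclopropyl or a piperidine ring on the amide-type nitrogen would read. Also open, from the compounds shown here alone, is how far the half-life of compound 1 lies past its limit.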